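Antiproliferative series: nitro for methyl on the benzyl ring

The source may hold more compounds than are shown below. What is called first, only, known or untested is meant among the compounds shown, and "the series" means these compounds.

Measured compounds:
- compound 1, `Cc1nn(-c2ccccc2)c(Oc2ccc(Cl)cc2)c1/C=N/OCc1ccc(C(=O)OC(C)(C)C)cc1`: -6.5%
- compound 2, `Cc1ccc(CO/N=C/c2c(C)nn(C)c2Oc2ccc(Cl)cc2)cc1`: 50%
- compound 3, `Cc1nn(C)c(Oc2ccccc2)c1/C=N/OCc1ccc(C(F)(F)F)cc1`: 34.7%

All three were run in a functional assay on A549 cells (Homo sapiens) for antiproliferative activity, tested at 1 uM; a lower number here means less inhibition, a higher number more inhibition at the concentration tested (going by the name of the read-out). Compound 2 stands highest of the three numbers: compound 3 lies closest, with a number lower by an amount beyond the scatter, and compound 1 lies furthest, with a number lower by an amount well beyond the scatter. For the measured compounds named here, no single-change pair exists among the measured compounds, so no step within the set can be read directly; the three values only show the spread that this set of analogues covers.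

The next compound, compound 4, `Cc1nn(C)c(Oc2ccc(Cl)cc2)c1/C=N/OCc1ccc([N+](=O)[O-])cc1`, is compound 2 with one change: nitro in place of methyl on an aromatic carbon. The benzyl end therefore keeps its size of a single ring but gains the nitro group where the methyl stood.

Nothing in the measured set shows what this exchange does in this assay. The compound 1 variant, with its large ester on that ring, gives a number far below compound 2, while compound 3, with a trifluoromethyl on that ring and no chloro on the phenoxy part, sits between them; neither pair is a single change. A modest step from compound 2 to compound 4, a number 10 percentage points lower from compound 2 to compound 4 (within the scatter), is expected, downward, and could fall within the scatter. Compound 4 is therefore estimated at 40%, with a range from 12% to 65%.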

Compound 4, a percentage reported as inhibition, at one concentration (the size of the read-out at that concentration, not a potency): 39.6%
Beside the measured number, compound 4's estimate is 0.4 percentage points above it, and the stated range covers the measured number.
By their numbers in this assay, from the lowest: compound 1; then compounds 3 and 4 (each within the scatter of the next); then compound 2.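

For the compounds shown here, the exchange of 4-methylphenyl for 4-nitrophenyl gives the first single-change step in this assay, with a number 10.4 percentage points lower from compound 2 to compound 4 (beyond the scatter) as a modest loss at this position. The position therefore responds to the change, but compound 4 at 39.6% still shows clear inhibition, so a nitro group on this aromatic carbon is compatible with activity at the concentration tested. No supporting data here bear on the reason for this step.

From the compounds shown here alone, whether an amine or a carboxylic acid on the same aromatic carbon would give a higher or lower number remains open. Going by these compounds, it is also open whether the same exchange gives a step of similar size in analogues without the chloro on the phenoxy part.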